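Does Losing the Bromo Group Move Antiproliferative Potency?

A few compounds are considered here, and "the series" means these few. Any claim that something is new, unique, unknown or untested is made for them only; others in the source may bear on it.

The compounds are compared in a functional assay on MCF7 cells (Homo sapiens) for antiproliferative activity, read by MTT assay, with a stated time of 72 h; a higher number here means a weaker inhibitor, a lower number a stronger inhibitor. Compound 1 `O=C(COc1ccc(C(=O)/C=C/c2ccccc2Br)cc1)N[C@H]1CCOC1=O` gives 15300 nM in this assay. Compound 2 `O=C(CNc1ccc(Cl)cc1Cl)N[C@H]1CCOC1=O` sits at the limit of > 64000 nM in this assay, at which 1 of the 2 values shown sits, reported only as > 64000 nM. Compound 1 therefore holds the only number shown, the other entry being a limit rather than a measurement.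

Compound 3 `O=C(COc1ccc(C(=O)/C=C/c2ccccc2)cc1)N[C@H]1CCOC1=O` has not yet been tested. It differs from compound 1 by hydrogen in place of bromo on an aromatic carbon. Within the data shown here, no measured pair here differs in a single place, so no step size is available to lean on. The expectation is that this change moves the reading little, at most slightly toward a weaker inhibitor, and the estimated step of a 1.3-fold higher number from compound 1 to compound 3 (0.12 log units; within the scatter) is expected to stay within the usual scatter. Compound 3 is accordingly expected to give about 20000 nM in this assay, somewhere between 7000 nM and 60000 nM.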

Compound 3, half-maximal inhibitory concentration: > 64000 nM
Compound 3 gave a limit, no number (the forecaster's own chance of this, stated with the estimate: 25%); at least 3.2-fold (0.50 log units) between middle value and limit.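

Among these compounds, compound 1 and compound 3 form the first measured pair here that differs in a single place, and in this assay hydrogen in place of bromo gives an at least 4.1-fold higher number from compound 1 to compound 3 (0.62 log units; beyond the scatter). The aromatic carbon that carries the bromo group is therefore not indifferent to this change, since the 2-bromophenyl group of compound 1 gives a measurable reading and the phenyl group of compound 3 does not. Going by these compounds, the reading of compound 3 is a limit and not a number, so the step is only a floor and its full size stays unknown: the limit of > 64000 nM in this assay, at which 2 of the 3 values shown sit.

The compounds shown leave open whether a chlorine atom, a methyl group or a methoxy group on that aromatic carbon would keep the reading of compound 1. On these data alone, it also stays open how much of the step belongs to bromine itself rather than to any group at this place.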